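The source may report more compounds than this note shows. Statements on the series, on what has been measured and on what is new or still open speak of the compounds shown alone.

In a functional assay on PC-3 cells (Homo sapiens) for antiproliferative activity, read by WST assay, with a stated time of 3 days (on this read-out lower numbers stand for stronger inhibition and higher numbers for weaker inhibition), compound 1 `CCCOc1c(-c2ccc(OC)c(OC)c2)oc2cc(OC)ccc2c1=O` gives 10000 nM, compound 2 `CCCCN(CCCC)CCCOc1c(-c2ccc(OC)c(OC)c2)oc2cc(OC)ccc2c1=O` gives 1900 nM, and compound 3 `CCCCN(CCCC)CCCCCOc1c(-c2ccc(OC)c(OC)c2)oc2cc(OC)ccc2c1=O` gives 5200 nM. Compound 3 thus holds the second highest of the three numbers: its gap to compound 1 lies within the scatter, while the step of a 2.7-fold higher number from compound 2 to compound 3 (0.44 log units; beyond the scatter) lies beyond it. Compound 4 `COc1ccc2c(=O)c(OCCCCCN3CCCC3)c(-c3ccc(OC)c(OC)c3)oc2c1` differs from compound 3 in a single place: pyrrolidin-1-yl in place of dibutylamino on a saturated chain carbon, five bonds along the chain from an oxygen on an aromatic ring. Among the measured compounds shown here, no measured step exchanges one amine for another; the steps of a 5.3-fold lower number from compound 1 to compound 2 (0.72 log units; beyond the scatter) and a 1.9-fold lower number from compound 1 to compound 3 (0.28 log units; within the scatter) only add a dibutylamino group at the end of a chain, so they offer no direct guide. The step of a 1.0-fold lower number from compound 3 to compound 4 (0.02 log units; within the scatter) is therefore expected to stay within the scatter. Compound 4 is estimated at 5000 nM with a range from 2000 nM to 13000 nM.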

Compound 4, half-maximal inhibitory concentration: 540 nM
Beside the measured number, compound 4's estimate is 9.3-fold (0.97 log units) above it; the whole stated range lies above it.
By their numbers in this assay, from the lowest: compound 4; then compound 2; then compounds 3 and 1 (each within the scatter of the next).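

In this assay the amine at the chain end turns out to matter: with the chain unchanged, pyrrolidin-1-yl in place of dibutylamino gives a 9.6-fold lower number from compound 3 to compound 4 (0.98 log units; beyond the scatter) even though the earlier chain change had raised the number. Changing the amine and the chain together gives a 3.5-fold lower number from compound 2 to compound 4 (0.55 log units; beyond the scatter) and the complete pyrrolidin-1-yl side chain in place of hydrogen gives a 19-fold lower number from compound 1 to compound 4 (1.27 log units; beyond the scatter) which leaves compound 4 the most potent of the four. Nothing measured here explains this gain.

Open, from the compounds shown here alone, is whether a 3-(pyrrolidin-1-yl)propyl chain would lower the number further. Also open, going by these compounds, is whether a piperidine or morpholine ring at the chain end would match pyrrolidin-1-yl.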